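The compounds below may be only part of what the source reports. "The series", "measured", "known", "first", "only" and "open" are said of these compounds alone.

Compound 1 `CN1CCN(CCNC(=O)n2c(=O)n(Cc3ccccc3)c3ccccc32)CC1` was tested in a functional assay for agonist activity at 5-hydroxytryptamine receptor 4 (Cavia porcellus); on this read-out lower numbers stand for smaller maximal responses and higher numbers for larger maximal responses. In this assay compound 1 gives < 0.3, which is a limit of the assay rather than a number, (the limit of < 0.3 in this assay, at which 1 of the 3 values shown sits). Two related compounds were also measured: compound 2 `CCCN1CCN(CCNC(=O)n2c(=O)n(C3CC3)c3ccccc32)CC1` gives 0.41 in this assay, and compound 3 `CC(C)n1c(=O)n(C(=O)NCCN2CCN(C)CC2)c2cc(Cl)ccc21` gives 0.7. Compound 4 `CCn1c(=O)n(C(=O)NCCN2CCN(C)CC2)c2ccccc21` has not yet been measured. It differs from compound 1 in one place: methyl in place of phenyl on a saturated chain carbon bound to an aromatic nitrogen. Both compound 2 and compound 3 carry a small group where compound 1 carries benzyl, and their values stand as numbers. On that basis the step is expected to go upward, beyond the scatter, estimated at a number at least 0.20 higher from compound 1 to compound 4 (beyond the scatter). Compound 4 is expected to give about 0.5 in this assay, within a range from 0.3 to 0.7.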

Compound 4, intrinsic activity: the largest response reached, as a fraction of the reference agonist's: < 0.3
Compound 4 ended at the assay's limit; the forecaster's own chance of this, stated with the estimate: 15%; middle value at least 0.20 away from the limit.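

Going by these compounds alone, compound 1 and compound 4 both end at a limit of the assay rather than at a number, so no step between them can be read: the limit of < 0.3 in this assay, at which 2 of the 4 values shown sit. In this assay the compounds shown leave open whether benzyl and ethyl differ at all.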